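The source may hold more compounds than are shown below. What is called first, only, known or untested is meant among the compounds shown, and "the series" means these compounds.

Measured compounds:
compound 1 `NC1=NC2(CCSCC2)N(OCCCOc2cccc(Cl)c2)C(N)=N1`, 130 nM
compound 2 `NC1=NC2(CCOCC2)N(OCCCOc2ccc(F)cc2)C(N)=N1`, "not determined" (no result reported)
compound 3 `NC1=NC2(CCOCC2)N(OCCCOc2cc(Cl)c(Cl)cc2Cl)C(N)=N1`, "not determined" (no result reported)

The series shares a core carrying two amino groups, with a chain ending in an aryl ether. Among the compounds with values here, in a functional assay on MDA-MB-231 cells (Homo sapiens) for antiproliferative activity, read by MTT assay, with a stated time of 72 h (a higher number here means a weaker inhibitor, a lower number a stronger inhibitor), compound 1 gives 130 nM, the only number in the set. Compound 2 stands without a number in this assay, its entry reading "not determined" (no result reported), and compound 3 likewise has no result, its entry being "not determined" (no result reported). So where compound 2 stands cannot be said from its own measurement; the only anchor for the whole set is compound 1.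

Compound 4 `NC1=NC2(CCOCC2)N(OCCCOc2cccc(Cl)c2Cl)C(N)=N1` is not yet measured. It differs from compound 2 by 2,3-dichlorophenyl in place of 4-fluorophenyl on an oxygen on a saturated carbon. Within the data shown here, no measured pair shows this change, so the size of the step from compound 2 to compound 4 in this assay cannot be taken from the data. Given that compound 1, which also carries chlorine on the aryl ring, gives 130 nM, compound 4 is expected to fall in the same region, with a wide range to allow for the lack of a direct comparison. The estimate for compound 4 in this assay is 150 nM, expected between 40 nM and 600 nM.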

Compound 4, half-maximal inhibitory concentration: 140 nM
Estimate against measurement, compound 4: 1.1-fold (0.03 log units) above, and the stated range covers the measured number.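

Within the data shown here, compound 4 gives 140 nM in this assay, but compound 2 has no number there, so no step from compound 2 to compound 4 can be read. Nothing measured here bears on the cause of this result. The compounds shown leave open how 2,3-dichlorophenyl and 4-fluorophenyl compare on the shared core in this assay.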